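Swapping the Aryl Group on a Ring Nitrogen of Compound 3

A few compounds are considered here, and "the series" means these few. Any claim that something is new, unique, unknown or untested is made for them only; others in the source may bear on it.

Of the compounds shown here, three have been measured in an assay on Sf9 cells for inhibition of protein deacetylase HDAC6 (Homo sapiens), read by fluorescence, with a stated time of 40 min, tested at 100 nM; a higher number here means more inhibition at the concentration tested (going by the name of the read-out), a lower number less inhibition. Compound 1 `Cc1ccc(-n2nc(-c3ccccc3)nc2CNc2ccc(C(=O)NO)cc2)cc1` gives 60.7%, compound 2 `Cc1cccc(-n2nc(-c3ccccc3)nc2CNc2ccc(C(=O)NO)cc2)c1` gives 66%, and compound 3 `CC(C)c1ccc(-n2nc(-c3ccccc3)nc2CNc2ccc(C(=O)NO)cc2)cc1` gives 52.6%. Compound 3 thus holds the lowest of the three numbers; its nearest neighbour is compound 1, separated by a number 8.1 percentage points lower from compound 1 to compound 3 (within the scatter), and its furthest is compound 2, separated by a number 13.4 percentage points lower from compound 2 to compound 3 (beyond the scatter). Compound 4 `O=C(NO)c1ccc(NCc2nc(-c3ccccc3)nn2-c2ccccc2Cl)cc1` remains unmeasured. It differs from compound 3 in one place: 2-chlorophenyl in place of 4-isopropylphenyl on an aromatic nitrogen. Within the data shown here, two measured steps touch the same group on the aromatic nitrogen. The replacement of methyl by isopropyl, a number 8.1 percentage points lower from compound 1 to compound 3 (within the scatter), stays within the scatter, whereas the change from 3-methylphenyl to 4-isopropylphenyl, a number 13.4 percentage points lower from compound 2 to compound 3 (beyond the scatter), lies beyond it and runs downward toward compound 3. Leaving 4-isopropylphenyl behind may therefore recover some of that ground, although 2-chlorophenyl has no direct precedent among these compounds. In this assay a modest upward step, a number 9.4 percentage points higher from compound 3 to compound 4 (within the scatter), is expected. Compound 4 is estimated at 62%, within a range from 48% to 76%.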

Compound 4, a percentage reported as inhibition, at one concentration (the size of the read-out at that concentration, not a potency): 64.6%
The estimate for compound 4 lay 2.6 percentage points below the measured number; the measured number falls inside the stated range.
By their numbers in this assay, from the lowest: compounds 3, 1, 4 and 2 (each within the scatter of the next, the first and the last beyond it).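

In this assay the result shows that an aryl group with its substituent on a different ring carbon, and with chlorine in place of carbon, can sit on this aromatic nitrogen, and that 2-chlorophenyl in place of 4-isopropylphenyl gives a number 12 percentage points higher from compound 3 to compound 4 (beyond the scatter) as a step. Set against the two methylphenyl compounds, the same position shows a number 1.4 percentage points lower from compound 2 to compound 4 (within the scatter) and a number 3.9 percentage points higher from compound 1 to compound 4 (within the scatter) so that 2-chlorophenyl cannot be told apart from 3-methylphenyl or 4-methylphenyl here. Nothing available on these compounds accounts for the step from 4-isopropylphenyl.

As far as these compounds go, whether a 3-chlorophenyl group, a 4-chlorophenyl group, a 2-methoxyphenyl group or a pyridine ring on this nitrogen would give a different number remains open. Each number is a reading at a single concentration, so the potency of these compounds also remains open.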